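Hydroxycarbamoyl series: the step from compound 1 to compound 3

The compounds below may be only part of what the source reports. "The series", "measured", "known", "first", "only" and "open" are said of these compounds alone.

compound 1 `COc1cc(NC(C)CCCCCCNC(=O)CCC(=O)NO)c2ncccc2c1` gives 1600 nM
compound 2 `COc1cc(NC(C)CCCNC(=O)CCC(=O)NO)c2ncccc2c1` gives 1600 nM

Both values come from a functional assay on U2OS cells (Homo sapiens) for inhibition, read by MTT assay, with a stated time of 72 h (on this read-out higher numbers stand for weaker inhibition and lower numbers for stronger inhibition), and place compound 1 level with compound 2, within the scatter. Compound 3 `COc1cc(NC(C)CCCCCNC(=O)CCC(=O)NO)c2ncccc2c1` has yet to be measured in this assay and is the next point in the series. Going from compound 1 to compound 3, ((2-(hydroxycarbamoyl)ethyl)carbonyl)amino takes the place of (((2-(hydroxycarbamoyl)ethyl)carbonyl)amino)methyl on a saturated chain carbon, six bonds along the chain from a nitrogen on an aromatic ring ((2-(hydroxycarbamoyl)ethyl)carbonyl)amino in place of (((2-(hydroxycarbamoyl)ethyl)carbonyl)amino)methyl on a saturated chain carbon, six bonds along the chain from a nitrogen on an aromatic ring while the rest of the structure stays the same. Within the data shown here, no measured step in one place is available as a guide. Among the measured compounds shown here, the only evidence is that compound 1 at 1600 nM and compound 2 at 1600 nM show no gap. A step of no change at the digits printed from compound 1 to compound 3 (within the scatter) is therefore expected, in neither direction and not beyond the scatter. For compound 3 the estimated value is 1600 nM with an expected range from 800 nM to 3200 nM in this assay.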

Compound 3, half-maximal inhibitory concentration: 3300 nM
For compound 3 the middle estimate is 2.1-fold (0.31 log units) below the measured one; the whole stated range lies below it.
By their numbers in this assay, from the lowest: compounds 1 and 2 (each within the scatter of the next); then compound 3.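

In this assay, ((2-(hydroxycarbamoyl)ethyl)carbonyl)amino in place of (((2-(hydroxycarbamoyl)ethyl)carbonyl)amino)methyl gives a 2.1-fold higher number from compound 1 to compound 3 (0.31 log units; beyond the scatter), so this position does respond to a change from 10 heavy atoms to 9 in the leaving and entering groups. The matching values of compound 1 and compound 2 therefore cannot be read as a flat response to chain length, since compound 3 at 3300 nM stands apart from both. Nothing available accounts for this step.

Whether the response continues with a chain longer than that of compound 1 remains open, and the three points shown do not define a trend. Also open, from the compounds shown here alone, is how the series behaves with a carboxylic acid in place of the hydroxycarbamoyl group on the same chain.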